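A cyclohexyl in place of propyl

This account rests on a few compounds, and the source may have more. Where it says the series, first, only, none or still open, it means among the compounds named here.

Measured in an ADME assay on MDBK cells (Bos taurus) for cytotoxicity, read by MTT assay; on this read-out higher numbers stand for lower toxicity in this test and lower numbers for higher toxicity in this test:
compound 1 `CCCC1CCCCC1OCCCCCCN1C[C@H](O)[C@@H](O)[C@H](O)[C@H]1CO`: 150000 nM
compound 2 `OC[C@@H]1[C@@H](O)[C@H](O)[C@@H](O)CN1CCCCCCOc1cc(F)ccc1F`: > 500000 nM
Not yet measured: compound 3 `OC[C@@H]1[C@@H](O)[C@H](O)[C@@H](O)CN1CCCCCCOC1CCCCC1C1CCCCC1`

Among the compounds with values here, compound 1 holds the only exact number in this assay. For compound 2, > 500000 nM is a limit of the assay. Compound 3 carries cyclohexyl in place of propyl on a saturated ring carbon. Within the data shown here, the sole measured step, an at least 3.3-fold higher number from compound 1 to compound 2 (0.52 log units; beyond the scatter), replaced that whole saturated ring, which compound 3 keeps, and it bears on this change only loosely. No step beyond the scatter is therefore expected in this assay. The estimated step is a 1.4-fold lower number from compound 1 to compound 3 (0.13 log units; within the scatter). For compound 3 the expected value is 110000 nM, within a range of 40000 nM to 300000 nM.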

Compound 3, half-maximal cytotoxic concentration: 200000 nM
The estimate for compound 3 lay 1.8-fold (0.26 log units) below the measured number; the range from low to high includes it.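

In this assay, the step of a 1.3-fold higher number from compound 1 to compound 3 (0.12 log units; within the scatter) shows that cyclohexyl in place of propyl on this saturated ring carbon leaves the number within the scatter. The earlier step had replaced the whole saturated ring, whereas this one changes only its substituent, and this position, next to the ring atom that bears a large group, takes a second ring as readily as the chain. Nothing shown here gives a cause for this result. Going by these compounds, whether an amine or a carboxylic acid on the same ring carbon would keep the number within the scatter stays open. So does the effect of a phenyl ring there.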